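The compounds below may be only part of what the source reports. "The series", "measured", "known", "first", "only" and "open" are said of these compounds alone.

Measured so far in an assay on Jurkat cells for inhibition of nuclear factor NF-kappa-B p105 subunit (Homo sapiens); a lower number here means a stronger inhibitor, a higher number a weaker inhibitor:
compound 1 `O=C(Nc1cc(Cl)cc(Cl)c1)c1cncnc1C(F)(F)F` gives > 10000 nM, a limit of the assay rather than a number.
compound 2 `NC(=O)c1cc(NC(=O)c2cnc(Cl)nc2C(F)(F)F)cc(C(F)(F)F)c1` gives 5000 nM.

Going by the values given here, compound 2 thus holds the only numerical value among the two; the other is the limit of > 10000 nM in this assay, at which 1 of the 2 values shown sits. Compound 3 `CCCCCCCCOC(=O)c1cc(NC(=O)c2cnc(Cl)nc2C(F)(F)F)cc(C(F)(F)F)c1` differs from compound 2 in one place: octyloxy in place of amino on a carbonyl carbon. Among the compounds with values here, no step between two measured compounds bears on this change, so the size and direction of the move in this assay are uncertain; a step not beyond the usual scatter is the expectation, with a wider band around it. Compound 3 is therefore estimated at 6000 nM, in the range 1500 nM to 20000 nM, an expected step of a 1.2-fold higher number from compound 2 to compound 3 (0.08 log units; within the scatter).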

Compound 3, half-maximal inhibitory concentration: 1800 nM
Compound 3: middle estimate off by 3.3-fold (0.52 log units), on the high side, within the range that was stated.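

On this carbonyl carbon, octyloxy in place of amino gives a 2.8-fold lower number from compound 2 to compound 3 (0.44 log units; beyond the scatter) in this assay. The position therefore accepts a long chain and the loss of the carbamoyl hydrogen-bond donor, and inhibition does not weaken. Nothing measured here explains the step.

The compounds shown leave open whether the step follows from the octyl chain or from the ester carbonyl itself. A methyl ester, a carboxylic acid or an octyl amide on the same carbonyl carbon would bear on that question.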